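Removing a Methoxy Group from Compound 2

The source may report more compounds than this note shows. Statements on the series, on what has been measured and on what is new or still open speak of the compounds shown alone.

Among the measured compounds shown here, in an assay on isolated protein for inhibition of Maltase-glucoamylase (Homo sapiens) (a higher number here means a weaker inhibitor, a lower number a stronger inhibitor), compound 2 `COc1ccc(C(c2c(O)c3cc(Cl)ccc3oc2=O)c2c(O)c3cc(Cl)ccc3oc2=O)cc1O` gives 113000 nM, the higher of the two numbers measured so far. Compound 1 `O=c1oc2ccc(Cl)cc2c(O)c1C(c1cccc([N+](=O)[O-])c1)c1c(O)c2cc(Cl)ccc2oc1=O` gives 27100 nM in this assay. For the measured compounds named here, the only measured step, a 4.2-fold higher number from compound 1 to compound 2 (0.62 log units; beyond the scatter), exchanged the whole side ring rather than a single group. Compound 3 `O=c1oc2ccc(Cl)cc2c(O)c1C(c1cccc(O)c1)c1c(O)c2cc(Cl)ccc2oc1=O` differs from compound 2 by a smaller change: hydrogen in place of methoxy on an aromatic carbon. Going by the values given here, no measured step removes a methoxy group on its own, so that earlier step bears on this one only loosely. The step is therefore expected to be small, a 1.5-fold lower number from compound 2 to compound 3 (0.18 log units; within the scatter). Compound 3 is estimated at 75000 nM, likely between 25000 nM and 220000 nM.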

Compound 3, half-maximal inhibitory concentration: 84100 nM
Beside the measured number, compound 3's estimate is 1.1-fold (0.05 log units) below it; the range from low to high includes it.
By their numbers in this assay, from the lowest: compound 1; then compounds 3 and 2 (each within the scatter of the next).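

In this assay, removing the methoxy group gives a 1.3-fold lower number from compound 2 to compound 3 (0.13 log units; within the scatter), so this group counts for little at this position of the ring. Hydroxy in place of nitro gives a 3.1-fold higher number from compound 1 to compound 3 (0.49 log units; beyond the scatter), so most of the earlier gap remains without the methoxy group and goes with the exchange of nitro for hydroxy. On these data alone, whether an ethoxy group in the methoxy group's place, or an amine in place of the hydroxy group, would move the number stays open. Nothing available explains either step.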